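Sulfur-linked heterocycle swaps on the shared anilide core

This account rests on a few compounds, and the source may have more. Where it says the series, first, only, none or still open, it means among the compounds named here.

Measured so far:
compound 1 `Cn1c(-c2ccc(NC(=O)CSc3nc4ccccc4s3)cc2)nc(-c2ccccc2)c1-c1ccccc1` — 15.3%
compound 2 `Cc1nnc(SCC(=O)Nc2ccc(-c3nc(-c4ccccc4)c(-c4ccccc4)n3C)cc2)s1` — 39.9%

In a functional assay on HT-29 cells (Homo sapiens) for cytotoxicity, read by MTT assay, with a stated time of 24 h, tested at 1.6 ug/mL (on this read-out lower numbers stand for a weaker effect and higher numbers for a stronger effect at the one concentration tested), compound 2 gives 39.9%, the higher of the two numbers in hand. Compound 1 sits at 15.3%, and the step of a number 24.6 percentage points higher from compound 1 to compound 2 (beyond the scatter) is the only one recorded; it came from exchanging the group on the sulfur, 5-methyl-1,3,4-thiadiazol-2-yl in place of 1,3-benzothiazol-2-yl.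

Compound 3 `Cn1c(-c2ccc(NC(=O)CSC3=NCCS3)cc2)nc(-c2ccccc2)c1-c1ccccc1` is not yet measured. Compared with compound 2 it differs by a group of 5 heavy atoms (3 carbon, 1 nitrogen, 1 sulfur; one five-membered non-aromatic ring with 2 hetero atoms) in place of a group of 6 heavy atoms (3 carbon, 2 nitrogen, 1 sulfur; one five-membered aromatic ring with 3 hetero atoms), on a sulfur. Going by the values given here, the one known step bears on it only loosely: it shows that a smaller heteroaromatic ring on the same sulfur gave a modest rise, but nothing shows how a non-aromatic ring behaves there. The change from compound 2 to compound 3 removes the aromatic character at that position, so a step back towards compound 1 or none beyond the scatter is expected, giving a number 9.9 percentage points lower from compound 2 to compound 3 (within the scatter) in this assay. For compound 3 the estimate is 30%, with a range from 12% to 50%.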

Compound 3, a percentage reported as activity, at one concentration (the size of the read-out at that concentration, not a potency): 30.4%
The estimate for compound 3 lay 0.4 percentage points below the measured number; the measured number falls inside the stated range.
By their numbers in this assay, from the lowest: compound 1; then compounds 3 and 2 (each within the scatter of the next).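

With a five-membered non-aromatic ring on the sulfur in place of 5-methyl-1,3,4-thiadiazol-2-yl, this assay shows a number 9.5 percentage points lower from compound 2 to compound 3 (within the scatter), so among these compounds an aromatic ring at this position is not needed to keep the read-out level with that of the thiadiazole. Going by these compounds alone, the same ring also gives a number 15.1 percentage points higher from compound 1 to compound 3 (beyond the scatter), and together with a number 24.6 percentage points higher from compound 1 to compound 2 (beyond the scatter) this sets both single-ring groups apart from the two-ring 1,3-benzothiazol-2-yl, with no compound of the three going against that split. No measurement on hand explains why the two-ring group stands apart, and the three compounds cannot separate the second ring from the larger heavy-atom count.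

Still open, going by these compounds, is how an open-chain group on the sulfur, such as ethyl, or a six-membered ring, such as pyridin-2-yl, would read against these three. On these data alone, it is equally open whether an amine in place of the methyl on the thiadiazole would shift the number, and whether the split seen at this one concentration would hold at others.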